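Trifluoromethyl added to the distal phenyl of a boron-containing amide

This account rests on a few compounds, and the source may have more. Where it says the series, first, only, none or still open, it means among the compounds named here.

The account concerns a pair of amides that share one core. Compound 1 `C#Cc1ccccc1NC(=O)CCc1cccc2c1B(O)OC2` and compound 2 `O=C(CCc1cccc2c1B(O)OC2)Nc1cccc(-c2ccccc2)c1` were both tested in an ADME assay on WI-38 cells (Homo sapiens) for cytotoxicity, read by MTT assay, with a stated time of 72 h; on this read-out lower numbers stand for stronger inhibition and higher numbers for weaker inhibition. In this assay compound 1 gives 18000 nM, and compound 2 gives 12000 nM; the two numbers sit within the usual scatter of each other, so nothing separates the two compounds on this read-out. The next compound, compound 3 `O=C(CCc1cccc2c1B(O)OC2)Nc1cccc(-c2ccc(C(F)(F)F)cc2)c1`, has not yet been measured in this assay. It differs from compound 2 in one place: trifluoromethyl in place of hydrogen on an aromatic carbon. Among the compounds with values here, no measured pair here carries the same change, so there is no step on record to lean on. The step from compound 2 to compound 3 is expected to be small, a 1.3-fold lower number from compound 2 to compound 3 (0.12 log units; within the scatter), with the number for compound 3 at or a little under that of compound 2 rather than beyond the scatter. Compound 3 is therefore estimated at 9000 nM, with a range from 3000 nM to 30000 nM.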

Compound 3, half-maximal inhibitory concentration: 26000 nM
Compound 3: middle estimate off by 2.9-fold (0.46 log units), on the low side, within the range that was stated.
By their numbers in this assay, from the lowest: compounds 2, 1 and 3 (each within the scatter of the next, the first and the last beyond it).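

Within the data shown here, the change brings a 2.2-fold higher number from compound 2 to compound 3 (0.34 log units; beyond the scatter) in this assay and so gives the first single-place step on record at this carbon, para to a large group. It shows that this position of the distal phenyl does not tolerate every substituent without consequence: trifluoromethyl in place of hydrogen moves the number modestly towards weaker inhibition, and the step lies beyond the scatter. Nothing in the data available explains this rise.

From the compounds shown here alone, what remains open is whether this step is particular to trifluoromethyl, since a fluorine, a methoxy group, an amine or a carboxylic acid on the same carbon could move the number either way or not at all. Going by these compounds, it is also open whether the same change would give a similar step in other amides of the shared core.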